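This account rests on a few compounds, and the source may have more. Where it says the series, first, only, none or still open, it means among the compounds named here.

Measured compounds:
Compound 1, `c1ccc(-c2cn3ccnc3c(-c3ccc4ncn(C5CCCCC5)c4c3)n2)cc1`: 16.5%
Compound 2, `CCc1ccc(-c2cn3ccnc3c(-c3ccc4ncn(Cc5ccccc5)c4c3)n2)cc1`: 14.8%

Of the compounds shown here, two have so far been tested in a functional assay on SK-MEL-2 cells (Homo sapiens) for inhibition, read by sulforhodamine B assay, with a stated time of 48 h, tested at 10 uM; on this read-out higher numbers stand for more inhibition at the one concentration tested (going by the name of the read-out) and lower numbers for less inhibition. Compound 1 `c1ccc(-c2cn3ccnc3c(-c3ccc4ncn(C5CCCCC5)c4c3)n2)cc1` gives 16.5% there, and compound 2 `CCc1ccc(-c2cn3ccnc3c(-c3ccc4ncn(Cc5ccccc5)c4c3)n2)cc1` gives 14.8%. The two numbers sit within the usual scatter of each other, so neither stands apart from the other; both show only modest inhibition at the single concentration tested.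

Compound 3 `Cc1cccc(-c2cn3ccnc3c(-c3ccc4ncn(Cc5ccccc5)c4c3)n2)c1` has not yet been measured. It differs from compound 2 in one place: 3-methylphenyl in place of 4-ethylphenyl on an aromatic carbon. Among the compounds with values here, no pair of measured compounds differs in just one place, so there is no measured step to lean on, and the two values shown are all there is to go on. With both of them low and close together, the step from compound 2 to compound 3 is expected to be small, in no particular direction, and not beyond the scatter: a number 0.2 percentage points higher from compound 2 to compound 3 (within the scatter). For compound 3 the expected value in this assay is 15%, with a range from 4% to 30%.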

Compound 3, a percentage reported as inhibition, at one concentration (the size of the read-out at that concentration, not a potency): 6.34%
The estimate for compound 3 lay 8.7 percentage points above the measured number; the measured number falls inside the stated range.
By their numbers in this assay, from the lowest: compounds 3, 2 and 1 (each within the scatter of the next, the first and the last beyond it).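

Within the data shown here, this is the first measured step at this position on the shared core: in this assay, 3-methylphenyl in place of 4-ethylphenyl on an aromatic carbon gives a number 8.5 percentage points lower from compound 2 to compound 3 (within the scatter) and so stays within the usual scatter. Swapping these two carbon-only aromatic groups therefore does not show a clear effect on inhibition at the one concentration tested, and this single pair gives no sign that the position responds to such a swap. No measurement shown here offers an explanation for the number.

The step changes both the alkyl group and where it sits on the phenyl ring, and 4-methylphenyl or 3-ethylphenyl would be needed to tell those two changes apart. As far as these compounds go, it also remains open whether a phenyl ring carrying an amine, a carboxylic acid or a longer chain would move the read-out beyond the scatter.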